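Replacing the 2-methoxyethoxy group of compound 1

The source may hold more compounds than are shown below. What is called first, only, known or untested is meant among the compounds shown, and "the series" means these compounds.

- Compound 1 `COCCOc1ncc(C(=O)N[C@@H]2CCCC[C@H]2O)cc1-c1ccc(Cl)cc1`: 0.098 mL/min/kg
- Compound 2 `O=C(N[C@@H]1CCCC[C@H]1O)c1cnc(OCC2CC2)c(-c2ccc(F)cc2)c1`: 0.037 mL/min/kg

Both values come from an ADME assay (liver) for pharmacokinetics, with Liver microsome (Rattus norvegicus) as the target, read by LC-MS, using microsomes, tested at 2 uM (on this read-out lower numbers stand for slow clearance and higher numbers for fast clearance), and compound 1 holds the higher of the two, with compound 2 lying lower by more than the usual scatter. Compound 3 `CN(CC1CC1)c1ncc(C(=O)N[C@@H]2CCCC[C@H]2O)cc1-c1ccc(Cl)cc1` has not yet been measured. It keeps the core of compound 1 but carries (cyclopropylmethyl)(methyl)amino in place of 2-methoxyethoxy on an aromatic carbon, next to the ring nitrogen and ortho to a 4-chlorophenyl group, and (cyclopropylmethyl)(methyl)amino in place of 2-methoxyethoxy on an aromatic carbon sums up the change. For the measured compounds named here, no measured step isolates a change at this place, so the expectation is loose. In this assay no step beyond the scatter is expected, with a slight lean upward. The estimated step runs a 1.3-fold higher number from compound 1 to compound 3 (0.12 log units; within the scatter) and stays within that scatter. For compound 3 the expected value is 0.13 mL/min/kg (estimated range 0.04 mL/min/kg to 0.4 mL/min/kg).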

Compound 3, clearance: 1.73 mL/min/kg
The estimate for compound 3 lay 13-fold (1.12 log units) below the measured number; the whole stated range lies below it.
By their numbers in this assay, from the lowest: compound 2; then compound 1; then compound 3.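

In this assay, the place on an aromatic carbon next to the ring nitrogen proves far from indifferent to what it carries: (cyclopropylmethyl)(methyl)amino in place of 2-methoxyethoxy gives an 18-fold higher number from compound 1 to compound 3 (1.25 log units; beyond the scatter) on an otherwise unchanged core. For the compounds shown here, compound 2 differs from compound 1 in two places, so this is the first step that isolates a change at this position, and it shows that the exchange alone can move clearance well beyond the scatter. Nothing supplied explains the size of this step.

As far as these compounds go, whether the step follows the attached amine nitrogen itself or the cyclopropylmethyl and methyl groups it carries remains open. From the compounds shown here alone, how a dimethylamino group or a morpholine ring would read at this place also remains open.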